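The source may hold more compounds than are shown below. What is called first, only, known or untested is meant among the compounds shown, and "the series" means these compounds.

Three analogues that share one core have been examined in an assay on cells for binding affinity to Neuropeptide Y receptor type 1 (Homo sapiens); on this read-out higher numbers stand for weaker inhibition and lower numbers for stronger inhibition. Compound 1 `CCOc1cc(CCc2nc(C)c(CC)s2)nc(NCc2cc(Cl)cc(NC(=O)OC(C)C)c2)c1` gives 33 nM, compound 2 `CCc1sc(CCc2cc(OCC3(C)CC3)cc(NCc3cc(Cl)cc(NC(=O)OC(C)C)c3)n2)nc1C` gives 17 nM, and compound 3 `CCc1sc(CCc2cc(OC(CC)CC)cc(NCc3cc(Cl)cc(NC(=O)OC(C)C)c3)n2)nc1C` gives 5.5 nM, the lowest of the three numbers: its nearest neighbour is compound 2, with a 3.1-fold lower number from compound 2 to compound 3 (0.49 log units; beyond the scatter), and the furthest is compound 1, with a 6.0-fold lower number from compound 1 to compound 3 (0.78 log units; beyond the scatter). Compound 4 `CCc1sc(CCc2cc(OC3CCC3)cc(NCc3cc(Cl)cc(NC(=O)OC(C)C)c3)n2)nc1C` carries cyclobutyl in place of pentan-3-yl on an oxygen on an aromatic ring. Two measured steps changed this same group and bear on it, namely a 6.0-fold lower number from compound 1 to compound 3 (0.78 log units; beyond the scatter) and a 3.1-fold lower number from compound 2 to compound 3 (0.49 log units; beyond the scatter), whereas a 1.9-fold lower number from compound 1 to compound 2 (0.29 log units; within the scatter). Both steps ran toward pentan-3-yl, so replacing it with cyclobutyl is expected to give a modest shift toward a higher number in this assay, a 1.8-fold higher number from compound 3 to compound 4 (0.26 log units; within the scatter). Compound 4 is therefore estimated at 10 nM, with a range from 4 nM to 25 nM.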

Compound 4, half-maximal inhibitory concentration: 11 nM
Estimate against measurement, compound 4: 1.1-fold (0.04 log units) below; measured number inside the range.
By their numbers in this assay, from the lowest: compounds 3, 4, 2 and 1 (each within the scatter of the next, the first and the last beyond it).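

In this assay, cyclobutyl on the oxygen cannot be told apart from pentan-3-yl (a 2.0-fold higher number from compound 3 to compound 4 (0.30 log units; within the scatter)) or from (1-methylcyclopropyl)methyl (a 1.5-fold lower number from compound 2 to compound 4 (0.19 log units; within the scatter)), yet its step from ethyl lies beyond the scatter (a 3.0-fold lower number from compound 1 to compound 4 (0.48 log units; beyond the scatter)). A ring bound directly to the oxygen thus joins open-chain pentan-3-yl in standing clear of ethyl, which (1-methylcyclopropyl)methyl does not. Nothing given here explains these steps. Still open, from the compounds shown here alone, is how cyclopropyl or cyclopentyl on this oxygen would compare, and whether a chain ending in an amine or a hydroxyl would hold these numbers.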